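The compounds below may be only part of what the source reports. "The series", "measured", "known", "first", "only" and "open" are said of these compounds alone.

In a functional assay on A549 cells (Homo sapiens) for inhibition (on this read-out higher numbers stand for weaker inhibition and lower numbers for stronger inhibition), compound 1 (`COc1cc(/C=C\c2c[nH]c3ccccc23)cc(OC)c1OC`) gives 3230 nM and compound 2 (`COc1cc(/C=C/c2cn(C)c3ccccc23)cc(OC)c1OC`) gives 3090 nM, so compound 2 stands level with compound 1, within the scatter. Compound 3 (`COc1cc(/C=C\c2cn(C)c3ccccc23)cc(OC)c1OC`) is the next case: the two compounds have the same atoms and bonds and differ only in configuration as drawn: 1 of 1 stereo elements differ; a double bond is drawn E in compound 2 and Z in compound 3. Within the data shown here, no measured pair isolates this change. Compound 1, at 3230 nM, also has its double bond drawn Z, yet it differs from compound 2 in other ways, so only a moderate move toward lower numbers is expected, with wide uncertainty. The expected step is a 3.4-fold lower number from compound 2 to compound 3 (0.54 log units; beyond the scatter). For compound 3 the estimated value is 900 nM, with an expected range of 80 nM to 4000 nM.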

Compound 3, half-maximal inhibitory concentration: 3090 nM
For compound 3 the middle estimate is 3.4-fold (0.54 log units) below the measured one, within the range that was stated.
By their numbers in this assay, from the lowest: compounds 2, 3 and 1 (each within the scatter of the next).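

In this assay, among these compounds, the change from E to Z on the double bond gives no change at the digits printed from compound 2 to compound 3 (within the scatter) in the first pair to isolate configuration alone, so this pair shows no measurable dependence on the drawn geometry. With the double bond drawn Z, methyl in place of hydrogen on the aromatic nitrogen gives a 1.0-fold lower number from compound 1 to compound 3 (0.02 log units; within the scatter) and thus also leaves the number unmoved. These two pairs say nothing yet about whether the same holds for other groups on that nitrogen. As far as these compounds go, a longer chain or an amine-bearing chain there remains open, in either double-bond configuration.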